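Aminothiazole ketones: methoxy for chloro on the anilino ring

The source may hold more compounds than are shown below. What is called first, only, known or untested is meant among the compounds shown, and "the series" means these compounds.

The series is built on one shared core. Compound 1 `COc1ccc(Nc2nc(N)c(C(=O)c3ccccc3)s2)cc1` carries a benzoyl group and a methoxy-substituted anilino ring; in a functional assay on HeLa cells (Homo sapiens) for antiproliferative activity, read by cell counting, with a stated time of 2 days (a higher number here means a weaker inhibitor, a lower number a stronger inhibitor), compound 1 gives 230 nM. Compound 2 `Nc1nc(Nc2ccc(Cl)cc2)sc1C(=O)c1ccccc1` differs from it by methoxy in place of chloro on an aromatic carbon. For compound 2 this assay reports only a limit, > 10000 nM. The step of an at least 43-fold lower number from compound 2 to compound 1 (1.63 log units; beyond the scatter) is therefore large, though its true size is only bounded from one side because of the limit of > 10000 nM in this assay, at which 1 of the 3 values shown sits. Compound 3 `COc1cc(C(=O)c2sc(Nc3ccc(Cl)cc3)nc2N)cc(OC)c1OC` keeps the chloro-substituted anilino ring and differs from compound 2 in the benzoyl part; the difference between the two cores is not broken down here. In this assay compound 3 gives 180 nM, which sits within the scatter of compound 1.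

Compound 4 `COc1ccc(Nc2nc(N)c(C(=O)c3cc(OC)c(OC)c(OC)c3)s2)cc1` is not yet measured; it differs from compound 3 by methoxy in place of chloro on an aromatic carbon, the same change as that from compound 2 to compound 1. A lower number is expected for compound 4, with the step of a 4.5-fold lower number from compound 3 to compound 4 (0.65 log units; beyond the scatter) estimated smaller than the earlier one because an at least 43-fold lower number from compound 2 to compound 1 (1.63 log units; beyond the scatter) is only bounded from one side. Compound 3 already gives 180 nM, a low starting point. Compound 4 is estimated at 40 nM, with a likely range from 8 nM to 200 nM.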

Compound 4, half-maximal inhibitory concentration: 560 nM
Estimate against measurement, compound 4: 14-fold (1.15 log units) below, outside the stated range (above it).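

Methoxy in place of chloro on the anilino ring does not carry over from one core to the other in this assay. On the core of compound 3 the direction reverses, with a 3.1-fold higher number from compound 3 to compound 4 (0.49 log units; beyond the scatter), and the two steps are clearly different: the same change on two cores in this assay, an at least 43-fold lower number (1.63 log units; beyond the scatter) from compound 2 to compound 1 and a 3.1-fold higher number (0.49 log units; beyond the scatter) from compound 3 to compound 4, at least 130-fold (2.13 log units) apart, beyond the scatter of two such steps

This shows that the outcome of the change depends on the benzoyl part, but not which feature of that part is responsible, nor the full size of the earlier step, which rests on compound 2 being reported only as a limit: the limit of > 10000 nM in this assay, at which 1 of the 4 values shown sits.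

Open, as far as these compounds go, is whether a benzoyl group with a single methoxy would behave like the plain benzoyl of compound 1 or like the benzoyl part of compound 3. Also open, from the compounds shown here alone, is whether other groups on the anilino ring, such as fluoro, methyl or an amine, would depend on the benzoyl part in the same way.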